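One Ring Stereocentre Changed, Right at the Assay's Limit

The source may report more compounds than this note shows. Statements on the series, on what has been measured and on what is new or still open speak of the compounds shown alone.

Results so far in an ADME assay on Caco-2 cells (Homo sapiens) for metabolic stability, read by HPLC, with a stated time of 12 h (on this read-out higher numbers stand for a longer-lived compound and lower numbers for a shorter-lived compound), are:

- compound 1 `O=C(O)[C@H](CO)NC(=O)[C@H]1C[C@H](O)CN1` gives > 12 h
- compound 2 `O=C(O)[C@@H](CO)NC(=O)[C@H]1C[C@@H](O)CN1` gives > 12 h
- compound 3 `O=C(O)[C@@H](CO)NC(=O)[C@H]1C[C@H](O)CN1` gives > 12 h

Compound 3 gives > 12 h as its result, and that is a limit, not a number. All that can be read from the set is the limit of > 12 h in this assay, at which 3 of the 3 values shown sit, and nothing finer.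

Compound 4 `O=C(N[C@H](CO)C(=O)O)[C@@H]1C[C@H](O)CN1` has not been measured yet. Its difference from compound 3 is the two compounds have the same atoms and bonds and differ only in configuration as drawn: 1 of 3 stereo elements differ; a stereocentre at a saturated ring carbon is drawn R in compound 3 and S in compound 4 and nothing leaves or enters: a stereocentre at a saturated ring carbon is drawn R in compound 3 and S in compound 4.

The nearest parallel is a step that the two limits leave unreadable from compound 2 to compound 3 and it too changes a stereocentre at a saturated ring carbon. Also relevant are a step that the two limits leave unreadable from compound 1 to compound 3 at a saturated chain carbon and a step that the two limits leave unreadable from compound 1 to compound 2 at one carbon of each kind. None of these steps has a readable size, but every compound involved stays at the limit.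

No step beyond the usual scatter and no direction is therefore expected in this assay for this change, and a report of only a limit is likely. The estimated change is a step that the limit leaves unreadable from compound 3 to compound 4 with no expected direction. For compound 4 the estimate is 15 h with an expected range from 12 h to 24 h in repeat measurements.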

Compound 4, half-life: > 12 h
Compound 4 gave a limit, no number (the forecaster's own chance of this, stated with the estimate: 90%); the middle value does not contradict the limit.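

Compound 4 gives > 12 h, which is a limit and not a number. Compound 1, compound 2 and compound 3 sit at the same limit, so none of the steps to compound 4 can be read. The compounds shown leave open how long any of the four actually lasts in this assay, and whether changing the configuration alters the half-life at all.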